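Compound 4: 4-methylphenyl in place of 3-hydroxyphenyl

The source may hold more compounds than are shown below. What is called first, only, known or untested is meant among the compounds shown, and "the series" means these compounds.

Measured in an ADME assay on HeLa cells (Homo sapiens) for cytotoxicity, read by MTT assay, with a stated time of 72 h; on this read-out lower numbers stand for stronger inhibition of growth and higher numbers for weaker inhibition of growth:
- Compound 1 `O=C(/C=C\c1cccc(O)c1)N1N=C(c2ccncc2)OC1c1c[nH]c2ccccc12`: > 30 ug/mL
- Compound 2 `O=C(/C=C\c1ccc(O)cc1)N1N=C(c2ccncc2)OC1c1c[nH]c2ccccc12`: > 30 ug/mL
- Compound 3 `O=C(/C=C\c1cccc([N+](=O)[O-])c1)N1N=C(c2ccncc2)OC1c1c[nH]c2ccccc12`: > 30 ug/mL

Compound 1 stands only at a limit, > 30 ug/mL, and has no number of its own. Its two neighbours share that position, which is the limit of > 30 ug/mL in this assay, at which 3 of the 3 values shown sit.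

Compound 4 `Cc1ccc(/C=C\C(=O)N2N=C(c3ccncc3)OC2c2c[nH]c3ccccc23)cc1` keeps the core of compound 1 and differs in one place, (4-methylphenyl in place of 3-hydroxyphenyl on a double-bonded chain carbon bound to a double-bonded chain carbon). The new group carries no hydrogen-bond donor, unlike the group it replaces.

Among the measured compounds shown here, three measured steps bear on this change, all on the same aromatic group: a step that the two limits leave unreadable from compound 1 to compound 2, a step that the two limits leave unreadable from compound 1 to compound 3 and a step that the two limits leave unreadable from compound 2 to compound 3. None of them has a readable size, so they support no definite size or direction in this assay. The step expected is a step that the limit leaves unreadable from compound 1 to compound 4, and it is held loosely. Another limit is the likeliest report. As a number, the estimate for compound 4 is 45 ug/mL, with an expected range from 20 ug/mL to 100 ug/mL.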

Compound 4, concentration for 50% growth inhibition: > 30 ug/mL
Compound 4 was reported as a limit; the forecaster's own chance of this, stated with the estimate: 75%; the middle value lies beyond the limit too.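

Compound 4, like compound 1, compound 2 and compound 3, is reported only as a limit in this assay, and none of the steps to compound 4 can be read: the limit of > 30 ug/mL in this assay, at which 4 of the 4 values shown sit.

The compounds shown leave open whether any group at this place gives a measurable value in this assay, and how large any difference between these groups would be.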